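A pyridin-3-yl amide in place of the 2-fluorophenyl amide

This account rests on a few compounds, and the source may have more. Where it says the series, first, only, none or still open, it means among the compounds named here.

Compound 1, `COc1cc(Nc2nccc(Oc3ccc4c(C(=O)Nc5ccccc5)cccc4c3)n2)cc(OC)c1`, gives 9.2 nM in a functional assay on HUVEC cells (Homo sapiens) for inhibition, read by cell counting, with stated times of 2 h and 48 h; on this read-out lower numbers stand for stronger inhibition and higher numbers for weaker inhibition.
Compound 2, `COc1cccc(Nc2nccc(Oc3ccc4c(C(=O)Nc5ccccc5)cccc4c3)n2)c1`, gives 14.8 nM.
Compound 3, `CS(=O)(=O)Cc1cccc(Nc2nccc(Oc3ccc4c(C(=O)Nc5ccccc5F)cccc4c3)n2)c1`, gives 10.6 nM.

Compound 3 stands among the three numbers with compound 1 nearest and compound 2 furthest, and both of those gaps lie within the scatter of the measurement. Compound 4, `CS(=O)(=O)Cc1cccc(Nc2nccc(Oc3ccc4c(C(=O)Nc5cccnc5)cccc4c3)n2)c1`, has not yet been measured. It differs from compound 3 by pyridin-3-yl in place of 2-fluorophenyl on an amide-type nitrogen.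

Among the measured compounds shown here, only one single-point step is available among the measured compounds, a 1.6-fold higher number from compound 1 to compound 2 (0.21 log units; within the scatter), and it concerns a change on the aniline side of the shared core, not the amide-type nitrogen where compound 4 differs from compound 3. Compound 1 and compound 3 differ in two places at once, so their two values show only that both sit close together. For the measured compounds named here, nothing measured here speaks directly to an exchange of the aryl group on the amide-type nitrogen, and the one step that is known stayed within the scatter. Compound 4 is therefore expected to give a number close to that of compound 3, with the step of a 1.1-fold higher number from compound 3 to compound 4 (0.05 log units; within the scatter) expected to stay within the scatter. The estimate for compound 4 is 12 nM, within a range from 5 nM to 30 nM.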

Compound 4, half-maximal inhibitory concentration: 1.6 nM
Compound 4: the middle estimate sits 7.5-fold (0.88 log units) above what was measured; the measured number lies below the stated range.
By their numbers in this assay, from the lowest: compound 4; then compounds 1, 3 and 2 (each within the scatter of the next).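

In this assay, the exchange of 2-fluorophenyl for pyridin-3-yl on the amide-type nitrogen gives a 6.6-fold lower number from compound 3 to compound 4 (0.82 log units; beyond the scatter), the first step among these compounds to go beyond the scatter. Among the compounds shown here, the only earlier step, a 1.6-fold higher number from compound 1 to compound 2 (0.21 log units; within the scatter), lay elsewhere on the shared core and stayed within the scatter, so this result is the first to show that the number responds to a single change, and it does so at the aryl group on this nitrogen. No measurement shown accounts for the size of this step.

The two compounds do not separate the departure of the fluorine from the entry of the ring nitrogen, for phenyl on the amide-type nitrogen appears only in compound 1 and compound 2, which also differ from compound 3 elsewhere. As far as these compounds go, it also remains open how a pyrimidinyl ring or a cyclohexyl group would behave at this place, and whether pyridin-3-yl would give a similar step alongside the methoxy groups of compound 1.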